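Amide to benzylamine swap on the shared core

This account rests on a few compounds, and the source may have more. Where it says the series, first, only, none or still open, it means among the compounds named here.

Compound 1 `CC(C)c1cc(C(=O)N2CCc3c(sc(NC(=O)c4ccc(Cl)cc4)c3C#N)C2)[nH]n1` gives 12200 nM in a functional assay on Chem-3 cells for antagonist activity at metabotropic glutamate receptor 1 (Homo sapiens), read by fluorescence and calcium flux; a higher number here means a weaker inhibitor, a lower number a stronger inhibitor. Compound 2 `Cc1cc(C(=O)N2CCc3c(sc(NC(=O)c4ccc(Cl)cc4)c3C#N)C2)[nH]n1` records "not determined" (no result reported) in this assay, so compound 2 has no number to stand on; compound 1 is the only measured point near it. Compound 3 `Cc1cc(C(=O)N2CCc3c(sc(NCc4ccccc4)c3C#N)C2)[nH]n1` differs from compound 2 by benzyl in place of (4-chlorophenyl)carbonyl on a nitrogen on an aromatic ring. For the measured compounds named here, no measured step covers this change. Because compound 1 gives 12200 nM, a step toward weaker inhibition rather than stronger is expected for compound 3. Compound 3 is estimated at 25000 nM, with an expected range of 6000 nM to 100000 nM.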

Compound 3, half-maximal inhibitory concentration: 1420 nM
Compound 3: middle estimate off by 18-fold (1.25 log units), on the high side; the measured number lies below the stated range.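

No step can be read between compound 2 and compound 3, as compound 2 has no number in this assay. The compounds shown leave open what benzyl in place of (4-chlorophenyl)carbonyl does on its own. No evidence bears on this result.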